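Methoxy for methyl on a compound already past the assay limit

The source may report more compounds than this note shows. Statements on the series, on what has been measured and on what is new or still open speak of the compounds shown alone.

Compounds measured so far:
compound 1 `CNc1nc(-c2cc(OC)c(OC)c(OC)c2)c(-c2ccc(C)cc2)s1`, 10.1 nM 
compound 2 `CNc1nc(-c2cc(OC)c(OC)c(OC)c2)c(-c2ccc(OC)cc2)s1`, 37.6 nM 
compound 3 `COc1cc(-c2nc(N(C)C)sc2-c2ccc(C)cc2)cc(OC)c1OC`, > 10000 nM 

In a functional assay on MCF7 cells (Homo sapiens) for antiproliferative activity, read by MTT assay, with a stated time of 72 h (on this read-out higher numbers stand for weaker inhibition and lower numbers for stronger inhibition), compound 1 gives 10.1 nM, and compound 2 gives 37.6 nM. Among the compounds with values here, for compound 3 the result is only a limit of the assay, > 10000 nM, and it is the one value of the three that sits at the limit of > 10000 nM in this assay, at which 1 of the 3 values shown sits. Two steps connect these values: a 3.7-fold higher number from compound 1 to compound 2 (0.57 log units; beyond the scatter), and an at least 990-fold higher number from compound 1 to compound 3 (2.99 log units; beyond the scatter).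

Compound 4 `COc1ccc(-c2sc(N(C)C)nc2-c2cc(OC)c(OC)c(OC)c2)cc1` is not yet measured. It differs from compound 3 as follows: methoxy in place of methyl on an aromatic carbon. The same change was seen once before, going from compound 1 to compound 2, where a 3.7-fold higher number from compound 1 to compound 2 (0.57 log units; beyond the scatter); that step bears directly on what to expect here. The step from compound 1 to compound 3 shows how far compound 3 already lies beyond the range where a number is read.

Starting from a limit, a change that in the one measured instance raised the number further is not expected to bring compound 4 back into the measurable range. Compound 4 is therefore estimated at 30000 nM, with a range from 8000 nM to 120000 nM, most likely again reported only as a limit. The step this expectation means is a step that the limit leaves unreadable from compound 3 to compound 4.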

Compound 4, half-maximal inhibitory concentration: 8360 nM
Compound 4: the middle estimate sits 3.6-fold (0.55 log units) above what was measured; the range from low to high includes it.
By their numbers in this assay, from the lowest: compound 1; then compound 2; then compound 4. At a limit, above all of these: compound 3.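

In this assay compound 3 stands only at a limit, > 10000 nM. From there, the change from 4-methylphenyl to 4-methoxyphenyl gives an at least 1.1-fold lower number from compound 3 to compound 4 (0.07 log units; that floor lies within the scatter), so compound 4 has a readable number, and this floor does not repeat the rise the same change gave on the core of compound 1: the same change on two cores in this assay, a 3.7-fold higher number (0.57 log units; beyond the scatter) from compound 1 to compound 2 and an at least 1.1-fold lower number (0.07 log units; that floor lies within the scatter) from compound 3 to compound 4, at least 4.4-fold (0.64 log units) apart, beyond the scatter of two such steps The methyl in place of hydrogen on the nitrogen, until now sized only against a limit, also gets a readable step, a 220-fold higher number from compound 2 to compound 4 (2.35 log units; beyond the scatter), and it remains large with the 4-methoxyphenyl group in place: the same change on two cores in this assay, an at least 990-fold higher number (2.99 log units; beyond the scatter) from compound 1 to compound 3 and a 220-fold higher number (2.35 log units; beyond the scatter) from compound 2 to compound 4, at least 4.4-fold (0.64 log units) apart, beyond the scatter of two such steps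

On these data alone, it remains open whether an ethyl group or an acetyl group on that nitrogen would cost as much as the methyl does. As far as these compounds go, how a chlorine or a fluorine in place of the methoxy would behave on either core is equally open.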